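The source may hold more compounds than are shown below. What is called first, only, known or untested is meant among the compounds shown, and "the series" means these compounds.

In an ADME assay on HOS cells (Homo sapiens) for cytotoxicity, read by luminescence and ATP content, with a stated time of 48 h (a lower number here means that less compound is tolerated, a higher number that more compound is tolerated), compound 1 (`COc1ccc2c(N)c(C(=O)NCc3ccc(F)cc3F)c(=O)n(O)c2n1`) gives 2200 nM. Compound 3 (`Nc1c(C(=O)NCc2ccc(F)cc2F)c(=O)n(O)c2ncc(CCCCc3ccccc3)cc12`) gives 13000 nM, the higher of the two exact numbers, and its gap to compound 1 lies beyond the scatter. Compound 2 (`O=C(NCc1ccc(F)cc1F)c1c(O)c2cc(CCCCCO)cnc2n(O)c1=O`), whose chain carries no ring, reads > 250000 nM, which is a limit of the assay. Compound 4 (`CN(C)C(=O)CCc1cnc2c(c1)c(N)c(C(=O)NCc1ccc(F)cc1F)c(=O)n2O`) differs from compound 3 by dimethylcarbamoyl in place of phenethyl on a saturated chain carbon, two bonds along the chain from an aromatic carbon. Within the data shown here, no measured pair isolates this change, so only a modest move toward more compound being tolerated in this assay is expected, resting loosely on compound 2 at > 250000 nM. The expected step is a 2.3-fold higher number from compound 3 to compound 4 (0.36 log units; beyond the scatter). For compound 4, the estimated value is 30000 nM, with an expected range of 6000 nM to 150000 nM.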

Compound 4, half-maximal cytotoxic concentration: > 250000 nM
Compound 4 was reported as a limit; the forecaster's own chance of this, stated with the estimate: 20%; middle value at least 8.3-fold (0.92 log units) from the limit.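

In this assay, dimethylcarbamoyl in place of phenethyl on this saturated chain carbon gives an at least 19-fold higher number from compound 3 to compound 4 (1.28 log units; beyond the scatter). Among these compounds, this is the first pair to isolate a change at this position, and it shows that the chain end alone, with the rest of compound 3 unchanged, can produce a large step. The reading for compound 4 is a limit and not a number, so the true step remains unknown: the limit of > 250000 nM in this assay, at which 2 of the 4 values shown sit.

The compounds shown cannot separate the loss of the phenyl ring from the arrival of the dimethylcarbamoyl group. From the compounds shown here alone, how an amine or a carboxylic acid at this chain end would read remains open.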